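The source may hold more compounds than are shown below. What is called first, only, known or untested is meant among the compounds shown, and "the series" means these compounds.

Three compounds have been measured in a functional assay on cells (Rhabdomyosarcoma cell, Homo sapiens) for cytotoxicity; on this read-out higher numbers stand for weaker inhibition and lower numbers for stronger inhibition:
compound 1 `N#Cc1cccc(C(c2ccccc2)N2CCN(c3ncnc4c3cnn4-c3ccccc3)CC2)c1`: > 25000 nM
compound 2 `Cc1ccccc1C(c1sccc1C)N1CCN(c2ncnc3c2cnn3-c2ccccc2)CC1`: > 25000 nM
compound 3 `Cc1ccsc1C(c1ccccc1Br)N1CCN(c2ncnc3c2cnn3-c2ccccc2)CC1`: > 25000 nM

In this assay compound 1 gives > 25000 nM, which is a limit of the assay and not a number. Compound 2 gives > 25000 nM, likewise a limit. Compound 3 gives > 25000 nM, again a limit. All three values sit at the limit of > 25000 nM in this assay, at which 3 of the 3 values shown sit, so none of the three can be placed above or below another. Going by the values given here, the one step between measured compounds that differ in a single place, a step that the two limits leave unreadable from compound 2 to compound 3, is therefore of unknown size.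

Compound 4 `N#Cc1ccc(C(c2ccccc2)N2CCN(c3ncnc4c3cnn4-c3ccccc3)CC2)cc1` differs from compound 1 in one place: 4-cyanophenyl in place of 3-cyanophenyl on a saturated chain carbon bound to an amine nitrogen in a ring and an aromatic carbon. Among the compounds with values here, no measured step covers this kind of change, and the one step that exists was itself unreadable. The expectation for this assay can therefore rest only on where compound 1 stands. Compound 4 is expected to give 30000 nM, with a range of 10000 nM to 100000 nM, most likely reported again as a limit. The expected step, a step that the limit leaves unreadable from compound 1 to compound 4, is estimated as none beyond the scatter.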

Compound 4, half-maximal inhibitory concentration: > 25000 nM
Compound 4: a limit, no number; the forecaster's own chance of this, stated with the estimate: 80%; the middle value lies beyond the limit too.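

In this assay compound 4 gives > 25000 nM which is a limit and not a number. No step between compound 1 and compound 4 can be read, so the two cannot be ranked: the limit of > 25000 nM in this assay, at which 4 of the 4 values shown sit.

The compounds shown leave open whether any change to the shared core or its groups gives a value in this assay that is a number.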